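The source may hold more compounds than are shown below. What is called first, only, known or untested is meant among the compounds shown, and "the series" means these compounds.

Compound 1 `O=C(CCN1C(=O)CSc2ccccc21)N1CCN(c2ccc(C(F)(F)F)cc2)CC1` sits at the weak end of the pair measured so far. Among the compounds with values here, in a functional assay on IMR-32 cells (Homo sapiens) for inhibition, read by sulforhodamine B assay, with a stated time of 48 h (a lower number here means a stronger inhibitor of growth, a higher number a weaker inhibitor of growth), compound 1 gives 46400 nM, the highest of the two numbers known, while compound 2 `O=C(CCN1C(=O)CSc2ccccc21)N1CCC(Cc2ccccc2)CC1` gives 100 nM in this assay; the two differ in the whole amide-linked ring and its substituent, not in one place, so their gap says only that compound 1 is far the weaker inhibitor of growth of the two. Compound 3 `O=C(CCN1C(=O)CSc2ccccc21)N1CCN(c2ccccc2F)CC1` is not yet measured in this assay. Compound 3 differs from compound 1 by 2-fluorophenyl in place of 4-(trifluoromethyl)phenyl on an amine nitrogen in a ring and keeps the shared core and the ring with two nitrogens intact. Within the data shown here, no single-change step between measured compounds exists to anchor the expected size of this step. The change from compound 1 to compound 3 is expected to yield a moderate move toward a lower number, a 2.3-fold lower number from compound 1 to compound 3 (0.37 log units; beyond the scatter), though a result within the scatter of compound 1 at 46400 nM would not surprise. Compound 3 is therefore estimated at 20000 nM, with a range from 4000 nM to 80000 nM.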

Compound 3, concentration for 50% growth inhibition: > 100000 nM
Compound 3 ended at the assay's limit; the forecaster's own chance of this, stated with the estimate: 15%; middle value at least 5.0-fold (0.69 log units) away from the limit.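

The result for compound 3 is a limit of the assay and not a number: the limit of > 100000 nM in this assay, at which 1 of the 3 values shown sits.

Within the data shown here, replacing 4-(trifluoromethyl)phenyl with 2-fluorophenyl on an amine nitrogen in a ring gives an at least 2.1-fold higher number from compound 1 to compound 3 (0.33 log units; beyond the scatter), the first step that changes one place only, and its full size stays unknown. With the shared core and the ring with two nitrogens kept intact, this position is not silent in this assay, and this change moves the number away from stronger inhibition of growth rather than toward it.

The step changes the substituent on the phenyl ring and where it sits together, so the compounds shown do not tell which of the two carries the shift. Going by these compounds, how the position responds to a plain phenyl, a methoxy-bearing phenyl or a benzyl group on the same ring nitrogen remains open, as does whether any group there can bring the number down from that of compound 1.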